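The source may report more compounds than this note shows. Statements on the series, on what has been measured and on what is new or still open speak of the compounds shown alone.

Working notes on the series. Within the data shown here, compound 2 `COC(=O)c1c(Br)cccc1OC(=O)COc1cc(O)c2c(=O)cc(-c3ccccc3)oc2c1` gives in an ADME assay on cells (T-cell, Mus musculus, strain BALB/c) for cytotoxicity, read by MTT assay, with a stated time of 48 h (a lower number here means that less compound is tolerated, a higher number that more compound is tolerated), a value of 388000 nM, the highest of the two numbers measured so far. Its nearest neighbour is compound 1 `COC(=O)c1cccc(C)c1OC(=O)COc1cc(O)c2c(=O)cc(-c3ccccc3)oc2c1`, which in this assay gives 299000 nM; the step of a 1.3-fold higher number from compound 1 to compound 2 (0.11 log units; within the scatter) lies within the scatter, so the two compounds cannot be ordered on these numbers.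

The next compound, compound 3 `COC(=O)c1c(Cl)cccc1OC(=O)COc1cc(O)c2c(=O)cc(-c3ccccc3)oc2c1`, differs from compound 2 by chloro in place of bromo on an aromatic carbon, the exchange sitting on an aromatic carbon of a six-membered aromatic ring of carbon only, ortho to a methoxycarbonyl group and meta to a large group. Among the measured compounds shown here, the only measured step, from compound 1 to compound 2, changed the substitution of that same ring and moved this assay by a 1.3-fold higher number from compound 1 to compound 2 (0.11 log units; within the scatter), within the scatter. For the measured compounds named here, no step with chloro at this position has been measured. On that basis the exchange of one halogen for another is expected to move this assay by no more than the scatter, a 1.0-fold lower number from compound 2 to compound 3 (0.01 log units; within the scatter). Compound 3 is therefore estimated at 380000 nM in this assay, with a range from 200000 nM to 720000 nM.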

Compound 3, half-maximal cytotoxic concentration: 366000 nM
Beside the measured number, compound 3's estimate is 1.0-fold (0.02 log units) above it; the range from low to high includes it.
By their numbers in this assay, from the lowest: compounds 1, 3 and 2 (each within the scatter of the next).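

With chloro in place of bromo on an aromatic carbon, ortho to a methoxycarbonyl group, this assay gives a 1.1-fold lower number from compound 2 to compound 3 (0.03 log units; within the scatter), so this position now has a direct exchange of one halogen for another, and that exchange does not separate the two compounds. The larger exchange of the whole group on the oxygen next to a carbonyl group gives a 1.2-fold higher number from compound 1 to compound 3 (0.09 log units; within the scatter), and with this step all three pairs among the compounds shown lie within the scatter, so none of the three can be ordered against another. Nothing at hand bears on the reason for these small steps.

The compounds shown hold only chloro and bromo at this position, so it remains open whether an amine or a carboxylic acid there would give a step beyond the scatter. As far as these compounds go, it also remains open whether a longer chain in place of the methoxycarbonyl group, or any change to the shared core, would move the number in this assay by more than the scatter.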